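The source may hold more compounds than are shown below. What is called first, only, known or untested is meant among the compounds shown, and "the series" means these compounds.

Measured so far:
compound 1 `O=C(O)c1c(O)cccc1CCc1ccc2ccccc2c1` — > 100000 nM
compound 2 `O=C(O)c1c(O)cc(Cl)cc1CCc1ccc2ccccc2c1` — 35000 nM
compound 3 `COc1cc(Cl)cc(C=Cc2ccc3ccccc3c2)c1C(=O)O` — 93000 nM

In an ADME assay on HEK293 cells (Homo sapiens) for cytotoxicity, read by resazurin assay, with a stated time of 24 h (a lower number here means that less compound is tolerated, a higher number that more compound is tolerated), compound 2 gives 35000 nM and compound 3 gives 93000 nM, the highest of the two numbers. Compound 1 gives > 100000 nM, which is a limit of the assay and not a number. The change hydrogen in place of chloro on an aromatic carbon produced an at least 2.8-fold higher number from compound 2 to compound 1 (0.45 log units; beyond the scatter); the step is bounded by the limit of > 100000 nM in this assay, at which 1 of the 3 values shown sits. The difference between the cores of compound 2 and compound 3 is not broken down here.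

Compound 4 `COc1cccc(C=Cc2ccc3ccccc3c2)c1C(=O)O` carries the same kind of change, (hydrogen in place of chloro on an aromatic carbon); the place differs in being meta to a methoxy group rather than meta to a hydroxy group. The expected step is a 1.7-fold higher number from compound 3 to compound 4 (0.24 log units; within the scatter), resting on an at least 2.8-fold higher number from compound 2 to compound 1 (0.45 log units; beyond the scatter). Compound 4 is expected to give 160000 nM, between 70000 nM and 400000 nM, most likely reported as a limit.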

Compound 4, half-maximal cytotoxic concentration: > 100000 nM
Compound 4: only a limit was reported; the forecaster's own chance of this, stated with the estimate: 70%; the middle value is on the limit's open side.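

In this assay, hydrogen in place of chloro gives an at least 1.0-fold higher number from compound 3 to compound 4 (0.03 log units; that floor lies within the scatter). Compound 4 gives > 100000 nM, which is a limit of the assay and not a number. The step on this second core fits the earlier one but does not show that the change carries over with the same size: the same change on two cores in this assay, an at least 2.8-fold higher number (0.45 log units; beyond the scatter) from compound 2 to compound 1 and an at least 1.0-fold higher number (0.03 log units; that floor lies within the scatter) from compound 3 to compound 4; the limit leaves it open whether they differ

Still open, as far as these compounds go, is how a group other than chloro at this place, such as fluoro, methyl or an amine, would read in this assay. Also open, from the compounds shown here alone, is whether the change behaves the same way with an amide in place of the carboxy group.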